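Extending the Ethyl Chain of Compound 3 to Propyl

A few compounds are considered here, and "the series" means these few. Any claim that something is new, unique, unknown or untested is made for them only; others in the source may bear on it.

Measured compounds:
Compound 1, `Cc1nc(C)c2c(n1)N(Cc1ccc(-c3ccccc3-c3nn[nH]n3)cc1)CCC2`: -20%
Compound 2, `CCc1nc(C)nc2c1CCC(=O)N2Cc1ccc(-c2ccccc2-c2nn[nH]n2)cc1`: -104%
Compound 3, `CCc1nc(C)c2c(n1)N(Cc1ccc(-c3ccccc3-c3nn[nH]n3)cc1)C(=O)CC2`: -76%

Of the compounds shown here, three sharing the same biphenyl tetrazole side chain have been tested in a functional assay on the whole organism (artery) with Rattus norvegicus as the target, with a stated time of 60 min, at a dose of 3 mg/kg by the intraduodenal route; on this read-out higher numbers stand for more inhibition at the one dose given (going by the name of the read-out) and lower numbers for less inhibition. Compound 1 gives -20%, compound 2 gives -104%, and compound 3 gives -76%. On these numbers compound 3 stands second highest of the three. Its nearest neighbour is compound 2, whose value lies lower by a margin beyond the scatter; compound 1 lies furthest away, higher by a margin that is also beyond the scatter. Among the measured compounds shown here, none of the three pairs differs in only one place, so no single step between measured compounds can be read off.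

The next compound, compound 4, `CCCc1nc(C)c2c(n1)N(Cc1ccc(-c3ccccc3-c3nn[nH]n3)cc1)C(=O)CC2`, differs from compound 3 by methyl in place of hydrogen on a saturated chain carbon, two bonds along the chain from an aromatic carbon. The cores of compound 3 and compound 4 are otherwise the same, including the carbonyl that compound 3 shares with compound 2.

For the measured compounds named here, no measured pair isolates a change of this kind, so the step from compound 3 to compound 4 in this assay cannot be read from the measured compounds. The estimated step is a number 4 percentage points higher from compound 3 to compound 4 (within the scatter), a step that is not expected to go beyond the scatter in either direction. Compound 4 is therefore expected to give about -72%, within a range from -115% to -30%.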

Compound 4, a percentage reported as inhibition, in the whole organism at one dose (the size of the read-out at that dose, not a potency): -58%
The estimate for compound 4 lay 14 percentage points below the measured number; the measured number falls inside the stated range.
By their numbers in this assay, from the lowest: compound 2; then compound 3; then compound 4; then compound 1.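

In this assay, among the compounds shown here, the ethyl to propyl change on the shared core gives a number 18 percentage points higher from compound 3 to compound 4 (beyond the scatter), the first step that can be read from compounds differing in one place. It shows that this position, a saturated chain carbon two bonds along the chain from an aromatic carbon, is not silent: a single added methyl in place of hydrogen moves the read-out beyond the usual scatter, and upward, with compound 3 at -76% and compound 4 at -58%. The size of the move is modest and nothing available accounts for it, so the step stands as an observation without an explanation.

A single step cannot show whether the read-out would keep rising with a longer chain such as butyl, or whether it would level off or turn back there. The compounds shown also leave open how a branched chain such as isopropyl, a small ring such as cyclopropyl, or a chain carrying a methoxy group or an amine would behave at this same place on the core.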